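A hydroxy for a vinyl on the sulfonyl aryl group

A few compounds are considered here, and "the series" means these few. Any claim that something is new, unique, unknown or untested is made for them only; others in the source may bear on it.

Compound 2 `C=Cc1ccc(S(=O)(=O)Nc2ccc(-c3nc4ccccc4o3)cc2)cc1` carries a 4-vinylphenyl on its sulfonyl sulfur. In an assay on isolated protein for inhibition of malate dehydrogenase, mitochondrial (Sus scrofa), with stated times of 45 min and 30 min (a higher number here means a weaker inhibitor, a lower number a stronger inhibitor), compound 2 gives > 63000 nM, which is a limit of the assay and not a number. Its neighbour compound 1 `O=S(=O)(Nc1ccc(-c2nc3ccccc3o2)cc1)c1ccc(Cl)s1` differs only in the group on the sulfonyl sulfur. In this assay compound 1 gives > 63000 nM, again a limit. The step that the two limits leave unreadable from compound 1 to compound 2 therefore cannot be read, and the limit of > 63000 nM in this assay, at which 2 of the 2 values shown sit, sums up all that is known. Compound 3 `O=S(=O)(Nc1ccc(-c2nc3ccccc3o2)cc1)c1ccc(O)cc1` has not been measured; it changes compound 2 by hydroxy in place of vinyl on an aromatic carbon. Going by the values given here, no measured step touches this change, and the one step recorded is unreadable, so no size or direction can be taken from the data. Compound 3 is expected to sit near the same limit, an estimated 80000 nM with a range from 15000 nM to 400000 nM. The expected step is a step that the limit leaves unreadable from compound 2 to compound 3.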

Compound 3, half-maximal inhibitory concentration: > 63000 nM
Compound 3 gave a limit, no number; the forecaster's own chance of this, stated with the estimate: 80%; the middle value does not contradict the limit.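

Compound 3 gives > 63000 nM in this assay, a limit of the assay and not a number. The steps among compound 1, compound 2 and compound 3 therefore cannot be read. The compounds shown leave open what any group on the sulfonyl sulfur does to inhibition, with one result for all: the limit of > 63000 nM in this assay, at which 3 of the 3 values shown sit.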